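This account rests on a few compounds, and the source may have more. Where it says the series, first, only, none or still open, it means among the compounds named here.

Going by the values given here, compound 2 `COc1ccc2c(c1)C(n1ccccc1=O)=CC(C)(C)O2` gives 6.55 in a functional assay (aorta) with Rattus norvegicus as the target (on this read-out lower numbers stand for lower potency and higher numbers for higher potency (the scale is a negative logarithm)), and stands highest of the two numbers measured so far; its nearest neighbour, compound 1 `CC1(C)C=C(n2ccccc2=O)c2ccccc2O1`, gives 5.43. Among the compounds with values here, the one measured step, a number 1.12 log units higher from compound 1 to compound 2 (beyond the scatter), concerns the same aromatic carbon that is changed now and shows that a group there is well tolerated. Compound 3 `CC(=O)c1ccc2c(c1)C(n1ccccc1=O)=CC(C)(C)O2` differs from compound 2 by acetyl in place of methoxy on an aromatic carbon. Within the data shown here, no measured step compares two different groups at this carbon, so the direction is uncertain. Compound 3 is therefore expected to show only a number 0.15 log units lower from compound 2 to compound 3 (within the scatter). In this assay compound 3 is estimated at 6.4, ranging from 5.6 to 7.2.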

Compound 3, logarithm of the reciprocal of the active concentration, log(1/C): 7.37
Beside the measured number, compound 3's estimate is 0.97 log units below it, outside the stated range (above it).
By their numbers in this assay, from the lowest: compound 1; then compound 2; then compound 3.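

In this assay this aromatic carbon now has a direct comparison of two groups: acetyl in place of methoxy gives a number 0.82 log units higher from compound 2 to compound 3 (beyond the scatter), so the number here depends on which group is present and not merely on a group being there. Acetyl in place of hydrogen gives a number 1.94 log units higher from compound 1 to compound 3 (beyond the scatter), which exceeds the earlier step for methoxy in place of hydrogen. No evidence on hand accounts for this difference between acetyl and methoxy. As far as these compounds go, whether an amine, a carboxylic acid or a longer chain at this carbon would give a higher or lower number stays open. So does whether other carbons of the shared core respond in the same way.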